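Sulfonate ester series: urea extension at the anilide

The source may report more compounds than this note shows. Statements on the series, on what has been measured and on what is new or still open speak of the compounds shown alone.

Compound 1 `CCC(=O)Nc1cccc(S(=O)(=O)Oc2ccccc2C(C)C)c1` and compound 2 `CC(=O)Nc1ccc(S(=O)(=O)Oc2ccccc2C(C)C)cc1` share the sulfonate ester core. In a functional assay on M21 cells (Homo sapiens) for antiproliferative activity, read by sulforhodamine B assay, with a stated time of 48 h (on this read-out higher numbers stand for weaker inhibition and lower numbers for stronger inhibition), compound 1 gives 25000 nM, and in this assay compound 2 gives 21000 nM; the two values sit within the usual scatter of each other, so neither can be set above the other. Compound 3 `CCCCCNC(=O)Nc1ccc(S(=O)(=O)Oc2ccccc2C(C)C)cc1` differs from compound 2 by pentylamino in place of methyl on a carbonyl carbon. Within the data shown here, no step between measured compounds is available to guide the size of this change; a step of roughly similar weak inhibition, or at most a small gain, is expected here. For compound 3 the expected step is a 1.4-fold lower number from compound 2 to compound 3 (0.15 log units; within the scatter), and the estimate for compound 3 in this assay is 15000 nM, within 4000 nM to 60000 nM.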

Compound 3, half-maximal inhibitory concentration: 4600 nM
Compound 3: middle estimate off by 3.3-fold (0.51 log units), on the high side; the range from low to high includes it.
By their numbers in this assay, from the lowest: compound 3; then compounds 2 and 1 (each within the scatter of the next).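

In this assay, among these compounds, pentylamino in place of methyl on the carbonyl carbon gives a 4.6-fold lower number from compound 2 to compound 3 (0.66 log units; beyond the scatter), the first step that lies beyond the scatter. The position therefore accepts the larger (pentylcarbamoyl)amino group in place of acetamido, and activity improves modestly. Nothing available bears on the reason for this gain.

Among the compounds shown here, the single step does not separate the contribution of the added nitrogen from that of the pentyl chain. A hexanoyl amide, which has carbon in place of that nitrogen, would address this, while ethylamino and octylamino groups would show how the step depends on chain length.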